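From 4-methoxybenzyl to 4-bromobenzyl on the shared core

The source may report more compounds than this note shows. Statements on the series, on what has been measured and on what is new or still open speak of the compounds shown alone.

- compound 1 `COc1ccc(CN(C(=O)CSC(=S)N2CCN(C(=O)OC(C)(C)C)CC2)c2cc(OC)c(OC)c(OC)c2)cc1`: 620 nM
- compound 2 `COc1ccc(CN(C(=O)CSC(=S)N2CCN(C(=O)OC(C)(C)C)CC2)c2ccc(Cl)cc2)cc1`: > 20000 nM (a limit)
- compound 3 `COc1ccc(CN(C(=O)CSC(=S)N2CCN(C(=O)OC(C)(C)C)CC2)c2ccc(C)cc2)cc1`: > 20000 nM (a limit)

Within the data shown here, in a functional assay on HCT-116 cells (Homo sapiens) for inhibition, read by CCK-8 assay, with a stated time of 48 h (a higher number here means a weaker inhibitor, a lower number a stronger inhibitor), compound 1 gives 620 nM, the only actual number. The entries for compound 2 and compound 3 are limits.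

Compound 4 `COc1cc(N(Cc2ccc(Br)cc2)C(=O)CSC(=S)N2CCN(C(=O)OC(C)(C)C)CC2)cc(OC)c1OC` carries bromo in place of methoxy on an aromatic carbon. Among the measured compounds shown here, no measured step touches this group. The steps of an at least 32-fold higher number from compound 1 to compound 2 (1.50 log units; beyond the scatter) and an at least 32-fold higher number from compound 1 to compound 3 (1.50 log units; beyond the scatter) are large, but both replace the 3,4,5-trimethoxyphenyl, which compound 4 keeps. The step that the two limits leave unreadable from compound 2 to compound 3 cannot be read. No step beyond the scatter is therefore expected in this assay. The expected change is a 1.3-fold higher number from compound 1 to compound 4 (0.11 log units; within the scatter). The estimate for compound 4 is 800 nM, with an expected range of 200 nM to 4000 nM.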

Compound 4, half-maximal inhibitory concentration: 11400 nM
For compound 4 the middle estimate is 14-fold (1.15 log units) below the measured one; measured number outside the range, above it.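

In this assay, the 4-methoxybenzyl group proves not to be a silent part of the shared core: with the 3,4,5-trimethoxyphenyl kept, the change to 4-bromobenzyl gives an 18-fold higher number from compound 1 to compound 4 (1.26 log units; beyond the scatter). Among these compounds, the earlier large steps all lay on the other aryl group, so this is the first sign that the substituent on the benzyl ring also counts. Compound 2 and compound 3 offer only a limit and no number: the limit of > 20000 nM in this assay, at which 2 of the 4 values shown sit.

Only bromo is shown as a replacement for methoxy here. From the compounds shown here alone, how fluoro, hydroxy or an amine at this position would read stays open.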